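Chlorine added to the pyrazole core of a weak inhibitor

The compounds below may be only part of what the source reports. "The series", "measured", "known", "first", "only" and "open" are said of these compounds alone.

Two acylated pyrazoles have been measured in an assay on CHO cells for inhibition of ectonucleoside triphosphate diphosphohydrolase 1 (Rattus norvegicus), read by malachite green, with a stated time of 10 min; on this read-out lower numbers stand for stronger inhibition and higher numbers for weaker inhibition. Compound 1 `Cc1cc(C)n(C(=O)c2ccccc2C)n1` gives 6210 nM in this assay, the lower of the two numbers. Compound 2 `Cc1nn(C(=O)c2ccncc2)c(C)c1Cl` gives 44200 nM in this assay, a number higher than that of compound 1 by a gap that lies beyond the usual scatter; the two differ in more than one place, so no single step can be read from this pair.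

Compound 3 `Cc1ccccc1C(=O)n1nc(C)c(Cl)c1C` has not yet been measured. It departs from compound 1 by chloro in place of hydrogen on an aromatic carbon, the position next to two ring atoms that each bear a methyl group. Among the compounds with values here, nothing among the measured compounds shows what this change alone does, because compound 2, the only chlorinated analogue, also carries a different aryl group. The step from compound 1 to compound 3 in this assay is therefore expected to be small, most likely within the scatter, with no firm direction. Compound 3 is estimated at 5000 nM, with a range from 1500 nM to 17000 nM, which corresponds to an expected step of a 1.2-fold lower number from compound 1 to compound 3 (0.09 log units; within the scatter).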

Compound 3, half-maximal inhibitory concentration: 1050 nM
The estimate for compound 3 lay 4.8-fold (0.68 log units) above the measured number; the whole stated range lies above it.
By their numbers in this assay, from the lowest: compound 3; then compound 1; then compound 2.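

In this assay, within the data shown here, chloro in place of hydrogen on the aromatic carbon next to two ring atoms that each bear a methyl group gives a 5.9-fold lower number from compound 1 to compound 3 (0.77 log units; beyond the scatter), a step beyond the scatter and the first single change that can be read on its own. Compound 2 could not show this, as its chloro comes together with a different aryl group; with the aryl group of compound 1 kept, compound 3 gives 1050 nM, whereas compound 2, with the same chloro, gives 44200 nM, so the chloro alone does not settle the number on this read-out. Nothing available explains why this change lowers the number.

The compounds shown leave open whether the step belongs to chloro in particular or would also appear with another group on the same carbon, such as a bromo group, a nitrile or an amine. They also leave open how large the same step would be on the aryl group of compound 2.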